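Where a 4-methoxyphenyl group may take cytotoxicity

The compounds below may be only part of what the source reports. "The series", "measured", "known", "first", "only" and "open" are said of these compounds alone.

In a functional assay on PC-3 cells (Homo sapiens) for cytotoxicity, read by MTT assay, with a stated time of 72 h (on this read-out higher numbers stand for weaker inhibition and lower numbers for stronger inhibition), the measured compounds read as follows:

- Compound 1 `CNC(=O)c1cc(Oc2ccc(NC(=O)c3cc(-c4ccc(Br)cc4)ncn3)cc2)ccn1` gives > 100000 nM (a limit of the assay, not a number)
- Compound 2 `CNC(=O)c1cc(Oc2ccc(NC(=O)c3nccc(-c4ccc([N+](=O)[O-])cc4)n3)cc2)ccn1` gives > 100000 nM (a limit of the assay, not a number)
- Compound 3 `CNC(=O)c1cc(Oc2ccc(NC(=O)c3nccc(-c4cccc(Cl)c4)n3)cc2)ccn1` gives 20800 nM (a measured number)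

Compound 3 is the only one of the three with an actual number, since the other two values are limits. Compound 4 `CNC(=O)c1cc(Oc2ccc(NC(=O)c3nccc(-c4ccc(OC)cc4)n3)cc2)ccn1` has not been measured yet. It carries 4-methoxyphenyl in place of 3-chlorophenyl on an aromatic carbon and otherwise matches compound 3.

Among the measured compounds shown here, one measured step bears on this place. Putting 3-chlorophenyl where 4-nitrophenyl stood gave an at least 4.8-fold lower number from compound 2 to compound 3 (0.68 log units; beyond the scatter) and so the group here can move the number beyond the scatter. The 4-methoxyphenyl of compound 4 shares only the numbered place of its substituent with the 4-nitrophenyl of compound 2, so this comparison is thin support. Also relevant is the limit of > 100000 nM in this assay, at which 2 of the 3 values shown sit, as a ceiling close to the expected result.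

A higher number, meaning weaker inhibition, is therefore expected in this assay for the new compound. The expected size of the change is a 2.4-fold higher number from compound 3 to compound 4 (0.38 log units; beyond the scatter) with considerable uncertainty. For compound 4 the estimated value is 50000 nM with an expected range from 15000 nM to 100000 nM on this scale, and a result reported only as a limit would be no surprise.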

Compound 4, half-maximal inhibitory concentration: 14200 nM
The estimate for compound 4 lay 3.5-fold (0.55 log units) above the measured number; the measured number lies below the stated range.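

In this assay, 4-methoxyphenyl in place of 3-chlorophenyl gives a 1.5-fold lower number from compound 3 to compound 4 (0.17 log units; within the scatter), so this position does not separate these two groups, even though the entering group carries a hydrogen-bond acceptor that the leaving group lacks. Methoxy in place of nitro gives an at least 7.0-fold lower number from compound 2 to compound 4 (0.84 log units; beyond the scatter), and unlike the earlier change from 4-nitrophenyl to 3-chlorophenyl, this one keeps the number in the group's name, so only the substituent on the phenyl ring differs. That step starts from a limit of the assay and not a number, and such a limit still frames this small set: the limit of > 100000 nM in this assay, at which 2 of the 4 values shown sit.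

The compounds shown leave open whether 4-chlorophenyl or 3-methoxyphenyl would read differently from compound 3 and compound 4, which would separate the identity of the substituent from its numbered place on the phenyl ring. They also leave open whether a phenyl ring bearing an amine or a carboxylic acid would move the number beyond the scatter from compound 4 in this assay.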